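A few compounds are considered here, and "the series" means these few. Any claim that something is new, unique, unknown or untested is made for them only; others in the source may bear on it.

Compound 1 `COc1cc2c(cc1OC)CN(S(=O)(=O)c1ccc(-n3cc(COc4ccc5ccccc5c4)nn3)cc1)CC2` and compound 2 `COc1cc2c(cc1OC)CN(S(=O)(=O)c1ccc(-n3cc(COc4ccc(C)cc4)nn3)cc1)CC2` share one core and differ only in the group on an oxygen on a saturated carbon. In an ADME assay on Vero cells (Chlorocebus sabaeus) for cytotoxicity, with a stated time of 4 days (a higher number here means a weaker inhibitor, a lower number a stronger inhibitor), compound 1 gives > 50 ug/mL, which is a limit of the assay rather than a number. In this assay compound 2 gives > 50 ug/mL, again a limit rather than a number. The step that the two limits leave unreadable from compound 1 to compound 2 cannot be read, because both of its ends sit at the limit of > 50 ug/mL in this assay, at which 2 of the 2 values shown sit. Among the compounds with values here, compound 2 therefore stands at the limit, where every value shown so far also sits, and no compound in this set has given a number in this assay.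

Compound 3 `COc1cc2c(cc1OC)CN(S(=O)(=O)c1ccc(-n3cc(COc4cc(C=O)ccc4OC)nn3)cc1)CC2` has not yet been measured in this assay. It differs from compound 2 by 5-formyl-2-methoxyphenyl in place of 4-methylphenyl on an oxygen on a saturated carbon. Within the data shown here, the only measured step touches the same position, and its size is unreadable, so nothing in the measured data points to a direction. Compound 3 is expected to remain at the limit, with an estimate of 70 ug/mL within 35 ug/mL to 150 ug/mL. The step that the limit leaves unreadable from compound 2 to compound 3 that this estimate means is expected to be none beyond the scatter.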

Compound 3, half-maximal inhibitory concentration: > 50 ug/mL
Compound 3 gave a limit, no number (the forecaster's own chance of this, stated with the estimate: 80%); the middle value is on the limit's open side.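

In this assay compound 3 gives > 50 ug/mL, again a limit and not a number. Its steps from compound 2 and from compound 1 therefore cannot be read: the limit of > 50 ug/mL in this assay, at which 3 of the 3 values shown sit. The compounds shown leave open whether the group on the oxygen changes this read-out at all, and at what concentration any of the three would reach half-maximal inhibition.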